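Swapping a Sulfur Substituent Across Two Scaffolds

This account rests on a few compounds, and the source may have more. Where it says the series, first, only, none or still open, it means among the compounds named here.

Compound 2 `Cc1ccc(S/C(=C/c2sccc2C)C(=O)c2ccc(Cl)cc2)cc1` and compound 1 `Cc1ccsc1/C=C(/SCc1ccc(Cl)c(Cl)c1)C(=O)c1ccc(Cl)cc1` share one core and differ at a single sulfur: 3,4-dichlorobenzyl in place of 4-methylphenyl on a sulfur. In a functional assay on DU-145 cells (Homo sapiens) for inhibition, read by trypan blue exclusion, with a stated time of 96 h (on this read-out higher numbers stand for weaker inhibition of growth and lower numbers for stronger inhibition of growth), compound 2 gives 50000 nM, and compound 1 gives 50000 nM; the step of no change at the digits printed from compound 2 to compound 1 (within the scatter) shows that this swap left growth inhibition where it was. Compound 3 `COc1cc(OC)c(/C=C(/Sc2ccc(C)cc2)C(=O)c2ccc(Cl)cc2)c(OC)c1` carries a different core; how that core differs from the core of compound 2 is not broken down here. In this assay compound 3 gives > 100000 nM, which is a limit of the assay rather than a number, (the limit of > 100000 nM in this assay, at which 1 of the 3 values shown sits). Compound 4 `COc1cc(OC)c(/C=C(/SCc2ccc(Cl)c(Cl)c2)C(=O)c2ccc(Cl)cc2)c(OC)c1` differs from compound 3 by the same change at the same place: 3,4-dichlorobenzyl in place of 4-methylphenyl on a sulfur. Because the step of no change at the digits printed from compound 2 to compound 1 (within the scatter) showed no change, an equally small step is expected here: a number no higher from compound 3 to compound 4 (the limit leaves the size open). Compound 4 is therefore estimated at 100000 nM, within 50000 nM to 200000 nM, and will quite possibly again return only a limit.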

Compound 4, concentration for 50% growth inhibition: 10000 nM
Estimate against measurement, compound 4: 10-fold (1.00 log units) above; the measured number lies below the stated range.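

On the core of compound 3, the swap gives an at least 10-fold lower number from compound 3 to compound 4 (1.00 log units; beyond the scatter), so growth inhibition is stronger after the swap on this core, unlike on the core of compound 2. The same change therefore does not carry over unchanged from one core to the other in this assay: the same change on two cores in this assay, no change at the digits printed (within the scatter) from compound 2 to compound 1 and an at least 10-fold lower number (1.00 log units; beyond the scatter) from compound 3 to compound 4, at least 10-fold (1.00 log units) apart, beyond the scatter of two such steps. This does not show the exact size of the new step or why the two cores behave differently, and compound 3 stands only as a limit of the assay: the limit of > 100000 nM in this assay, at which 1 of the 4 values shown sits.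

The compounds shown leave open how either core would respond to other groups on the sulfur, such as a plain benzyl or a longer chain ending in an amine.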